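Chain extension on the amide of compound 1

The source may hold more compounds than are shown below. What is called first, only, known or untested is meant among the compounds shown, and "the series" means these compounds.

Compound 1 `CCC1C(=O)N(C)c2cnc(-n3ccc4cc(C(=O)NC)ccc43)nc2N1c1ccn(C)n1` is the reference point of these notes. In a functional assay on A549 cells (Homo sapiens) for antiproliferative activity, read by CCK-8 assay, with a stated time of 72 h (on this read-out lower numbers stand for stronger inhibition of growth and higher numbers for weaker inhibition of growth), compound 1 gives 43100 nM, the highest of the two numbers recorded for the series. Compound 3 `CCCCNS(=O)(=O)c1ccc(Nc2ncc3c(n2)N(C2CCCC2)[C@H](CC)C(=O)N3C)cc1` gives 477 nM in this assay, a far lower number, and the gap between the two lies beyond the scatter; the two compounds differ in several places at once, so no single step accounts for it. Compound 2 `CCC1C(=O)N(C)c2cnc(Nc3ccc(S(N)(=O)=O)cc3)nc2N1c1ccn(C)n1` was reported in this assay as "not active" (no number reported), with no number given.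

Compound 4 `CCCNC(=O)c1ccc2c(ccn2-c2ncc3c(n2)N(c2ccn(C)n2)C(CC)C(=O)N3C)c1` has not been measured. It differs from compound 1 in one place, (ethyl in place of hydrogen on a saturated chain carbon bound to an amide-type nitrogen), so that the methylcarbamoyl of compound 1 becomes propylcarbamoyl. Among the compounds with values here, no pair of measured compounds shows this change, and its effect on the read-out is therefore unknown from the data at hand. Because compound 1 sits at 43100 nM in this assay, only a small movement is expected from a change of this kind. The expected step is a 1.2-fold lower number from compound 1 to compound 4 (0.09 log units; within the scatter), within the scatter and with no direction favoured. Compound 4 is accordingly estimated at 35000 nM in this assay, with a range from 12000 nM to 100000 nM.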

Compound 4, concentration for 50% growth inhibition: "not active" (no number reported)
For compound 4 the study gives words and no number; no gap can be computed for the estimate.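

Within the data shown here, compound 4 is reported in this assay as not active, in words and without a number, so no step from compound 1, at 43100 nM, can be read. The compounds shown leave open how far methylcarbamoyl to propylcarbamoyl moves the read-out on the shared core. No evidence at hand bears on this result.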